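Thiophen-2-yl amide in an acetogenin-like series

The source may report more compounds than this note shows. Statements on the series, on what has been measured and on what is new or still open speak of the compounds shown alone.

Compound 3 has the structure `CCCCCCCCCCCC[C@@H](O)[C@H]1CC[C@H]([C@H](O)CCCCCCCCCCNC(=O)c2ccnn2C)O1`. In a functional assay on DU-145 cells (Homo sapiens) for inhibition, read by colorimetric assay and sulforhodamine B assay, with a stated time of 48 h (on this read-out lower numbers stand for stronger inhibition of growth and higher numbers for weaker inhibition of growth), compound 3 gives 100000 nM, level with compound 1 (`CCCCCCCCCCCC[C@@H](O)[C@H]1CC[C@H]([C@H](O)CCCCCCCCCCNC(=O)c2cncs2)O1`), which gives 100000 nM; together these are the highest numbers of the three measured. Compound 2 (`CCCCCCCCCCCC[C@@H](O)[C@H]1CC[C@H]([C@H](O)CCCCCCCCCCNC(=O)c2ccsc2)O1`) stands apart with 2190 nM, and the step from compound 3 reads a 46-fold higher number from compound 2 to compound 3 (1.66 log units; beyond the scatter) when taken in the other direction, while the step of no change at the digits printed from compound 1 to compound 3 (within the scatter) shows that the two-heteroatom rings behave alike.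

Compound 4 (`CCCCCCCCCCCC[C@@H](O)[C@H]1CC[C@H]([C@H](O)CCCCCCCCCCNC(=O)c2cccs2)O1`) differs from compound 3 by thiophen-2-yl in place of 1-methyl-1H-pyrazol-5-yl on a carbonyl carbon. For the measured compounds named here, the steps that bear on this are a 46-fold lower number from compound 1 to compound 2 (1.66 log units; beyond the scatter) and a 46-fold higher number from compound 2 to compound 3 (1.66 log units; beyond the scatter), both of which separate a ring with a single sulfur from rings with two hetero atoms by a large margin. Compound 4 carries a single-sulfur ring, so a large drop in the number is expected, in the direction of compound 2, with a wider range because the attachment differs. Compound 4 is therefore estimated at 3000 nM (range 700 nM to 30000 nM), a step of a 33-fold lower number from compound 3 to compound 4 (1.52 log units; beyond the scatter).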

Compound 4, concentration for 50% growth inhibition: 2690 nM
Compound 4: the middle estimate sits 1.1-fold (0.05 log units) above what was measured; low and high end bracket the measured number.
By their numbers in this assay, from the lowest: compounds 2 and 4 (each within the scatter of the next); then compounds 1 and 3 (each within the scatter of the next).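

In this assay, moving the attachment on the thiophene ring gives a 1.2-fold higher number from compound 2 to compound 4 (0.09 log units; within the scatter) and so leaves this carbonyl carbon's substituent without a measurable preference between thiophen-2-yl and thiophen-3-yl. The large separation from the rings with 2 hetero atoms now holds for a second thiophene, with a 37-fold lower number from compound 3 to compound 4 (1.57 log units; beyond the scatter) and a 37-fold lower number from compound 1 to compound 4 (1.57 log units; beyond the scatter), so sulfur alone does not set the level: the 1,3-thiazol-5-yl amide, compound 1, also carries sulfur yet sits with compound 3. No measurement shown accounts for this separation.

As far as these compounds go, whether the ring nitrogen is what goes with the higher numbers remains open. A furan-2-yl or phenyl group on this carbonyl carbon would bear on that question, as would a substituted thiophene such as a 5-chlorothiophen-2-yl group.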